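The source may hold more compounds than are shown below. What is called first, only, known or untested is meant among the compounds shown, and "the series" means these compounds.

In a functional assay on MDA-MB-231 cells (Homo sapiens) for antiproliferative activity, read by CCK-8 assay, with a stated time of 72 h (a higher number here means a weaker inhibitor, a lower number a stronger inhibitor), compound 2 `Cc1cc(C)cc(C(=O)Nc2cccc(-c3oc4cc(-c5ccc(F)cc5)ccc4c(=O)c3O)c2)c1` gives 11900 nM; compound 1 `COc1ccc(C(=O)Nc2cccc(-c3oc4cc(-c5ccc(F)cc5)ccc4c(=O)c3O)c2)c(F)c1` gives 17600 nM, and the step of a 1.5-fold lower number from compound 1 to compound 2 (0.17 log units; within the scatter) leaves the two within the scatter of each other, so neither is set apart. Compound 3 `CCCc1ccc(C(=O)Nc2cccc(-c3oc4cc(-c5ccc(F)cc5)ccc4c(=O)c3O)c2)cc1` carries 4-propylphenyl in place of 3,5-dimethylphenyl on a carbonyl carbon. For the measured compounds named here, the only measured step touching this position, from compound 1 to compound 2, did not leave the scatter, and nothing measured points to a direction for the present change. For compound 3 the expected step is therefore a 1.0-fold higher number from compound 2 to compound 3 (0.00 log units; within the scatter), within the scatter. The estimate for compound 3 is 12000 nM, with a range from 5000 nM to 30000 nM.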

Compound 3, half-maximal inhibitory concentration: 32200 nM
Compound 3: middle estimate off by 2.7-fold (0.43 log units), on the low side, outside the stated range (above it).
By their numbers in this assay, from the lowest: compounds 2, 1 and 3 (each within the scatter of the next, the first and the last beyond it).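

In this assay, for the compounds shown here, the change to 4-propylphenyl from 3,5-dimethylphenyl gives a 2.7-fold higher number from compound 2 to compound 3 (0.43 log units; beyond the scatter) and is the first step on this carbonyl carbon to leave the scatter, though only modestly. Going by these compounds alone, the same group in place of 2-fluoro-4-methoxyphenyl gives a 1.8-fold higher number from compound 1 to compound 3 (0.26 log units; within the scatter) and stays inside it, so only the pair of compound 2 and compound 3 is set apart. No supporting data bear on the reason for this step.

Still open, as far as these compounds go, is how an aryl group bearing an amine or a carboxylic acid, or a chain longer than propyl, would read here. Also open, from the compounds shown here alone, is whether the step follows from the propyl chain entering or from the 3,5-dimethylphenyl group leaving.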